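The compounds below may be only part of what the source reports. "The series", "measured", "known", "first", "only" and "open" are said of these compounds alone.

Compound 1 `CCCNCc1cc(-c2c(C(=O)NCC)noc2-c2cc(C(C)C)c(O)cc2O)on1`: 117 nM
Compound 2 `CCNC(=O)c1noc(-c2cc(C(C)C)c(O)cc2O)c1-c1cc(C(N)=O)no1`: 79 nM
Compound 3 `CCNC(=O)c1noc(-c2cc(C(C)C)c(O)cc2O)c1-c1cc(C(=O)NC)no1`: 124 nM

In a functional assay on HCT-116 cells (Homo sapiens) for inhibition (a lower number here means a stronger inhibitor, a higher number a weaker inhibitor), compound 3 at 124 nM lies within the scatter of both other compounds. Compound 4 `CCNC(=O)c1noc(-c2cc(C(C)C)c(O)cc2O)c1-c1ccn(C(C)C)n1` carries 1-isopropyl-1H-pyrazol-3-yl in place of 3-(methylcarbamoyl)-1,2-oxazol-5-yl on an aromatic carbon. The nearest evidence is a set of smaller changes within that group: a 1.5-fold lower number from compound 1 to compound 2 (0.17 log units; within the scatter), a 1.1-fold higher number from compound 1 to compound 3 (0.03 log units; within the scatter) and a 1.6-fold higher number from compound 2 to compound 3 (0.20 log units; within the scatter). All three stayed within the scatter, but none exchanged the whole group, so they bear on this change only loosely. The expected result is therefore no shift beyond the scatter, with wide uncertainty. The estimated change is a 1.2-fold higher number from compound 3 to compound 4 (0.08 log units; within the scatter). Compound 4 is expected at 150 nM, within an estimated range of 50 nM to 450 nM.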

Compound 4, half-maximal inhibitory concentration: 19 nM
Estimate against measurement, compound 4: 7.9-fold (0.90 log units) above; the measured number lies below the stated range.
By their numbers in this assay, from the lowest: compound 4; then compounds 2, 1 and 3 (each within the scatter of the next).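

Exchanging the whole group at this position moves the number in this assay beyond the scatter, which changes on the 3-substituent of the 1,2-oxazol-5-yl group had not done: the exchange gives a 6.5-fold lower number from compound 3 to compound 4 (0.81 log units; beyond the scatter) and, in the same direction, a 4.2-fold lower number from compound 2 to compound 4 (0.62 log units; beyond the scatter) and a 6.2-fold lower number from compound 1 to compound 4 (0.79 log units; beyond the scatter) for the other two compounds. The 1,2-oxazol-5-yl group is therefore not required here for the lowest number of the set. Nothing available explains this gain.

From the compounds shown here alone, whether the pyrazole ring or its isopropyl group carries the step stays open. Also open, going by these compounds, is what a longer chain such as butyl in place of isopropyl would give.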